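The source may hold more compounds than are shown below. What is called first, only, known or untested is meant among the compounds shown, and "the series" means these compounds.

Measured so far:
- compound 1, `Clc1ccc(-c2nc(NCCNc3ccccn3)ncc2-c2ncc[nH]2)c(Cl)c1`: > 0.5 h
- compound 2, `Nc1nc(NCCNc2ncc(-c3ncc[nH]3)c(-c3cc(F)ccc3Cl)n2)ccc1[N+](=O)[O-]`: > 0.5 h

In an ADME assay on microsomes from liver (Rattus norvegicus) for metabolic stability (on this read-out higher numbers stand for a longer-lived compound and lower numbers for a shorter-lived compound), compound 1 reaches only a limit of the assay, > 0.5 h. Compound 2 likewise gives only a limit in this assay, > 0.5 h. Compound 2 therefore stands at the limit of > 0.5 h in this assay, at which 2 of the 2 values shown sit, with no number separating it from compound 1.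

Compound 3, `Cc1cc(Cl)ccc1-c1nc(NCCNc2ccc([N+](=O)[O-])c(N)n2)ncc1-c1ncc[nH]1`, carries 4-chloro-2-methylphenyl in place of 2-chloro-5-fluorophenyl on an aromatic carbon. Among the compounds with values here, no measured step covers a change of this kind, so no direction beyond the scatter is expected. The step that the limit leaves unreadable from compound 2 to compound 3 is expected to stay small. Compound 3 is expected at 1 h, between 0.4 h and 3 h.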

Compound 3, half-life: > 0.5 h
Compound 3: a limit, no number (the forecaster's own chance of this, stated with the estimate: 70%); the middle value is on the limit's open side.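

In this assay compound 2 and compound 3 both give only limits, so no step between them can be read: the limit of > 0.5 h in this assay, at which 3 of the 3 values shown sit.

The compounds shown leave open their actual half-lives, and whether 4-chloro-2-methylphenyl in place of 2-chloro-5-fluorophenyl changes the half-life at all.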